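The source may hold more compounds than are shown below. What is called first, only, known or untested is meant among the compounds shown, and "the series" means these compounds.

Measured in a functional assay on HCT-116 cells (Homo sapiens) for cytotoxicity, read by MTT assay, with a stated time of 72 h; on this read-out higher numbers stand for weaker inhibition and lower numbers for stronger inhibition:

- compound 1 `O=S(=O)(c1ccccc1)c1nc2ccccc2nc1N1CCCC(O)C1` gives 1390 nM
- compound 2 `O=S(=O)(c1ccc(F)cc1)c1nc2ccccc2nc1N1CCCC(O)C1` gives 5500 nM
- compound 3 `O=S(=O)(c1ccccc1)c1nc2ccccc2nc1N1CCC(O)CC1` gives 1870 nM

Compound 3, at 1870 nM, lies within the usual scatter of compound 1, at 1390 nM, while compound 2, at 5500 nM, gives a clearly higher number than either. The next compound, compound 4 `O=S(=O)(c1ccc(F)cc1)c1nc2ccccc2nc1N1CCC(O)CC1`, differs from compound 3 by one change, fluoro in place of hydrogen on an aromatic carbon, para to a large group.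

Going by the values given here, two measured steps bear on this. Among the compounds with values here, the same swap appears in a 4.0-fold higher number from compound 1 to compound 2 (0.60 log units; beyond the scatter), the only direct precedent, and it lies beyond the scatter. The other, a 1.3-fold higher number from compound 1 to compound 3 (0.13 log units; within the scatter), exchanges the hydroxypiperidine groups and stays within the scatter, so nothing here suggests that the swap should behave differently on compound 3. A similar rise in this assay is therefore expected, meaning weaker inhibition, though a single precedent leaves this uncertain. The expected change is a 3.5-fold higher number from compound 3 to compound 4 (0.54 log units; beyond the scatter). For compound 4 the estimated value is 6500 nM, with an expected range from 2800 nM to 14000 nM.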

Compound 4, half-maximal inhibitory concentration: 1340 nM
For compound 4 the middle estimate is 4.9-fold (0.69 log units) above the measured one, and the stated range ends above it.
By their numbers in this assay, from the lowest: compounds 4, 1 and 3 (each within the scatter of the next); then compound 2.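

Phenyl to 4-fluorophenyl now gives a 1.4-fold lower number from compound 3 to compound 4 (0.14 log units; within the scatter) in this assay, so this change has no single effect here, and its outcome differs with the hydroxypiperidine group present: the same change on two cores in this assay, a 4.0-fold higher number (0.60 log units; beyond the scatter) from compound 1 to compound 2 and a 1.4-fold lower number (0.14 log units; within the scatter) from compound 3 to compound 4, 5.5-fold (0.74 log units) apart, beyond the scatter of two such steps

Read the other way, 4-hydroxypiperidin-1-yl in place of 3-hydroxypiperidin-1-yl made no clear difference without the fluoro, yet with it the swap gives a 4.1-fold lower number from compound 2 to compound 4 (0.61 log units; beyond the scatter), so the two places do not act independently: the same change on two cores in this assay, a 1.3-fold higher number (0.13 log units; within the scatter) from compound 1 to compound 3 and a 4.1-fold lower number (0.61 log units; beyond the scatter) from compound 2 to compound 4, 5.5-fold (0.74 log units) apart, beyond the scatter of two such steps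

Of the four compounds, only compound 2, which pairs fluoro with 3-hydroxypiperidin-1-yl, stands apart, with a higher number than the other three.

These compounds cannot tell why the two changes depend on each other. As far as these compounds go, it also remains open whether the same dependence holds for a chloro or methoxy group in place of the fluoro, or for an amine in place of the hydroxyl.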